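The compounds below may be only part of what the source reports. "The series", "measured", "known", "first", "only" and "open" are said of these compounds alone.

Measured compounds:
Compound 1, `CCCC(Oc1ccc(-n2cc3ccccc3n2)cc1)c1ccc(C(=O)NCCC(=O)O)cc1`, gives 2000 nM in a functional assay on cells for antagonist activity at Glucagon receptor (Homo sapiens), read by cAMP accumulation, in the presence of a further agent that is not named here; a lower number here means a stronger inhibitor, a higher number a weaker inhibitor.
Compound 2, `CCCC(Oc1ccc(-n2cc(C(=O)N(C)C)cn2)cc1)c1ccc(C(=O)NCCC(=O)O)cc1`, gives > 30000 nM in this assay.

The value for compound 2 in this assay is a limit of the assay and not a number, as noted in the limit of > 30000 nM in this assay, at which 1 of the 2 values shown sits. Compound 2 therefore stands at the weak end of the two values shown.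

Compound 3, `CCCC(Oc1ccc(-n2cc(C#N)cn2)cc1)c1ccc(C(=O)NCCC(=O)O)cc1`, differs from compound 2 in one place: cyano in place of dimethylcarbamoyl on an aromatic carbon. Within the data shown here, the only measured step available is the one that leads from compound 1 to compound 2, which gives an at least 15-fold higher number from compound 1 to compound 2 (1.17 log units; beyond the scatter); it concerns a different group exchange on the same ring position, so it does not directly describe the change to cyano. Among the measured compounds shown here, with compound 2 already at the limit and no measured step of the cyano kind, the expected change from compound 2 to compound 3 in this assay is a number no higher from compound 2 to compound 3 (the limit leaves the size open), that is, little or none beyond the scatter. Compound 3 is therefore expected to give about 30000 nM in this assay, with a range from 8000 nM to 100000 nM, and a good chance that the assay again reports only a limit.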

Compound 3, antagonist equilibrium constant: > 50000 nM
Compound 3 ended at the assay's limit (the forecaster's own chance of this, stated with the estimate: 60%); middle value at least 1.6-fold (0.22 log units) away from the limit.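

In this assay compound 3 is also reported only as a limit of the assay, not as a number: the limit of > 50000 nM in this assay, at which 1 of the 3 values shown sits. The large drop from the 2H-indazol-2-yl group is therefore not peculiar to 4-(dimethylcarbamoyl)-1H-pyrazol-1-yl: 4-cyano-1H-pyrazol-1-yl, whose substituent has fewer heavy atoms and no carbonyl, also gives an at least 25-fold higher number from compound 1 to compound 3 (1.39 log units; beyond the scatter). The step between the two limits cannot be read, so the cyano and dimethylcarbamoyl groups cannot be placed in order, and neither group can be said to be the better of the two at this position.

The compounds shown leave open whether any other group on this aromatic carbon, such as an amine or a carboxylic acid in place of the cyano, could bring the value back towards that of compound 1, which gives 2000 nM. They also leave open whether a plain 1H-pyrazol-1-yl, carrying only a hydrogen there, would already lose as much as the two substituted versions, which would show whether the substituents or the loss of the 2H-indazol-2-yl group matter more.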